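The source may hold more compounds than are shown below. What is called first, only, known or untested is meant among the compounds shown, and "the series" means these compounds.

- compound 1 `Cc1cnc(C(=O)Nc2cc(F)cc3cccnc23)cn1`: > 10000 nM
- compound 2 `Cc1cnc(C(=O)Nc2cc(Cl)cc3cccnc23)cn1`: 5200 nM
- compound 3 `O=C(Nc1cc(F)cc2cccnc12)c1ncccn1`: not yet measured

In a functional assay on BXPC-3 cells (Homo sapiens) for inhibition, read by MTT assay, with a stated time of 72 h (a higher number here means a weaker inhibitor, a lower number a stronger inhibitor), compound 1 stands at > 10000 nM, which is a limit and not a number (the limit of > 10000 nM in this assay, at which 1 of the 2 values shown sits). Compound 3 carries pyrimidin-2-yl in place of 5-methylpyrazin-2-yl on a carbonyl carbon. Within the data shown here, the only measured step, an at least 1.9-fold lower number from compound 1 to compound 2 (0.28 log units; that floor lies within the scatter), is a different change, chloro in place of fluoro on an aromatic carbon, so it gives no size for this exchange. No step beyond the scatter is therefore expected in either direction. The expected step is a step that the limit leaves unreadable from compound 1 to compound 3. Compound 3 is estimated at 12000 nM, with an expected range of 5000 nM to 30000 nM.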

Compound 3, half-maximal inhibitory concentration: > 10000 nM
Compound 3: a limit, no number; the forecaster's own chance of this, stated with the estimate: 65%; the middle value lies beyond the limit too.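

In this assay compound 3 gives > 10000 nM, a limit and not a number. Among these compounds, compound 1 also stands at a limit, and no step from compound 1 to compound 3 can be read. The compounds shown leave open how pyrimidin-2-yl and 5-methylpyrazin-2-yl compare on the carbonyl carbon.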